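Replacing Methoxycarbonyl with 1-Hydroxyethyl: An Expected Value

The compounds below may be only part of what the source reports. "The series", "measured", "known", "first", "only" and "open" are said of these compounds alone.

Two compounds have so far been measured in an assay on HEK293 cells for displacement of a labelled ligand from prostaglandin D2 receptor 2 (Homo sapiens); on this read-out higher numbers stand for weaker inhibition and lower numbers for stronger inhibition:
Compound 1 `COc1ccc(C)cc1CSc1nc2ccccc2n1CC(=O)O` gives 1200 nM.
Compound 2 `COC(=O)c1ccc(OC)c(CSc2nc3ccccc3n2CC(=O)O)c1` gives 29 nM.

Going by the values given here, compound 2 stands at the lowest number of the two, and its only neighbour is compound 1, from which it is separated by the single measured step, a 41-fold lower number from compound 1 to compound 2 (1.62 log units; beyond the scatter). Compound 3 `COc1ccc(C(C)O)cc1CSc1nc2ccccc2n1CC(=O)O` has not yet been measured in this assay. It differs from compound 2 in one place: 1-hydroxyethyl in place of methoxycarbonyl on an aromatic carbon. Among the compounds with values here, the only step that bears on this position is the one between compound 1 and compound 2, and because a 41-fold lower number from compound 1 to compound 2 (1.62 log units; beyond the scatter) was large, whatever sits on this carbon evidently has a strong say in this assay. That step, however, compares only methyl with methoxycarbonyl and says nothing directly about 1-hydroxyethyl. With methoxycarbonyl leaving, a weaker binding than compound 2 is expected, though not necessarily as weak as compound 1. Compound 3 is therefore expected to give about 200 nM in this assay, within a range from 60 nM to 800 nM. This estimate corresponds to an expected step of a 6.9-fold higher number from compound 2 to compound 3 (0.84 log units; beyond the scatter).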

Compound 3, half-maximal inhibitory concentration: 2200 nM
The estimate for compound 3 lay 11-fold (1.04 log units) below the measured number; measured number above the stated range.
By their numbers in this assay, from the lowest: compound 2; then compounds 1 and 3 (each within the scatter of the next).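

In this assay, the strong result for methoxycarbonyl on this aromatic carbon does not carry over to 1-hydroxyethyl, with a 76-fold higher number from compound 2 to compound 3 (1.88 log units; beyond the scatter) showing that an oxygen-bearing group of similar size is not enough here. The change removes a double bond and one oxygen and brings in a hydrogen-bond donor, but these compounds cannot show which of these differences counts. Set against methyl, 1-hydroxyethyl cannot be told apart within the scatter, with a 1.8-fold higher number from compound 1 to compound 3 (0.26 log units; within the scatter) leaving methoxycarbonyl as the only one of the three groups that stands apart, and nothing measured here explains that difference.

The compounds shown leave open whether the whole methoxycarbonyl group is needed or whether its carbonyl would suffice, a question that acetyl, a carboxylic acid or a primary amide on the same carbon could help to answer. Going by these compounds, it also remains open whether a longer ester, such as ethoxycarbonyl, would keep the low number of compound 2, which would show how much room this position allows.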